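From a Cyclopropyl Ester to an Ethyl Chain

The source may hold more compounds than are shown below. What is called first, only, known or untested is meant among the compounds shown, and "the series" means these compounds.

- compound 1 `C/C=C(\C)C(=O)O[C@@H]1[C@]2(OC(=O)CCCC)C=C3C4=CC(=O)O[C@@H](c5ccoc5)[C@]4(C)CC[C@@H]3[C@@]3(C)[C@H](C[C@]1(C)[C@H]3[C@@H](O)C(=O)OC)O2`: 4000 nM
- compound 2 `C/C=C(\C)C(=O)O[C@@H]1[C@]2(OC(=O)C3CC3)C=C3C4=CC(=O)O[C@@H](c5ccoc5)[C@]4(C)CC[C@@H]3[C@@]3(C)[C@H](C[C@]1(C)[C@H]3[C@@H](O)C(=O)OC)O2`: > 100000 nM
- compound 3 `C/C=C(\C)C(=O)O[C@@H]1[C@]2(OC(=O)C3CC3)C=C3C4=CC(=O)O[C@@H](c5ccoc5)[C@]4(C)CC[C@@H]3[C@@]3(C)[C@H](C[C@]1(C)[C@H]3[C@@H](OC(=O)C1CC1)C(=O)OC)O2`: > 100000 nM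

These values come from a functional assay on COLO 205 cells (Homo sapiens) for inhibition, read by MTT assay, with a stated time of 24 h; on this read-out higher numbers stand for weaker inhibition and lower numbers for stronger inhibition. Compound 2 stands at > 100000 nM, which is a limit and not a number. Compound 3 gives > 100000 nM, also a limit. Together they make up (the limit of > 100000 nM in this assay, at which 2 of the 3 values shown sit).

Compound 4 `C/C=C(\C)C(=O)O[C@@H]1[C@]2(OC(=O)CC)C=C3C4=CC(=O)O[C@@H](c5ccoc5)[C@]4(C)CC[C@@H]3[C@@]3(C)[C@H](C[C@]1(C)[C@H]3[C@@H](O)C(=O)OC)O2` differs from compound 2 by one change: ethyl in place of cyclopropyl on a carbonyl carbon. It has ethyl in place of cyclopropyl on a carbonyl carbon. The closest evidence is an at least 25-fold higher number from compound 1 to compound 2 (1.39 log units; beyond the scatter), where cyclopropyl replaced butyl. The step that the two limits leave unreadable from compound 2 to compound 3 adds nothing here. Ethyl is an open chain like butyl, though not the same one, so a partial return towards compound 1 seems likely. The expected change is an at least 5.0-fold lower number from compound 2 to compound 4 (0.69 log units; beyond the scatter), towards stronger inhibition. Compound 4 is estimated at 20000 nM, within an expected range of 3000 nM to 100000 nM.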

Compound 4, half-maximal inhibitory concentration: > 100000 nM
Compound 4 was reported as a limit (the forecaster's own chance of this, stated with the estimate: 30%); middle value at least 5.0-fold (0.69 log units) from the limit.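

On a carbonyl carbon, ethyl does not behave like butyl: an at least 25-fold higher number from compound 1 to compound 4 (1.39 log units; beyond the scatter), so an open chain alone does not restore the inhibition seen with compound 1. Compound 4 gives > 100000 nM, a limit, and its step from compound 2 cannot be read. Only compound 1 now gives a number, and the others share one ceiling: the limit of > 100000 nM in this assay, at which 3 of the 4 values shown sit.

As far as these compounds go, whether a longer chain such as hexyl would match or exceed compound 1 stays open. So does what an amine at the end of the butyl chain would do.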